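A 4-Carbamoylphenyl Group Replaces 2-(Hydroxymethyl)phenyl

This account rests on a few compounds, and the source may have more. Where it says the series, first, only, none or still open, it means among the compounds named here.

In a functional assay on PC-3 cells (Homo sapiens) for inhibition, read by sulforhodamine B assay, with a stated time of 48 h, tested at 50 uM (a higher number here means more inhibition of growth at the concentration tested, a lower number less inhibition of growth), compound 1 `COc1ccc([C@@H]2C/C(=N/OCc3cn(-c4cccc(CO)c4)nn3)c3cc(CC=C(C)C)c(OC)cc3O2)cc1` gives 34% while compound 2 `COc1ccc([C@@H]2C/C(=N/OCc3cn(-c4ccccc4CO)nn3)c3cc(CC=C(C)C)c(OC)cc3O2)cc1` gives 100% and so stands higher of the two compounds measured. Compound 3 `COc1ccc([C@@H]2C/C(=N/OCc3cn(-c4ccc(C(N)=O)cc4)nn3)c3cc(CC=C(C)C)c(OC)cc3O2)cc1` keeps the shared core and differs from compound 2 on an aromatic nitrogen of a five-membered aromatic ring with 3 nitrogen, with 4-carbamoylphenyl in place of 2-(hydroxymethyl)phenyl (4-carbamoylphenyl in place of 2-(hydroxymethyl)phenyl on an aromatic nitrogen). Going by the values given here, the one measured step bearing on this is a number 66 percentage points higher from compound 1 to compound 2 (beyond the scatter) and it is large, with 2-(hydroxymethyl)phenyl in place of 3-(hydroxymethyl)phenyl. Among the compounds with values here, the only measured compound lacking the 2-(hydroxymethyl)phenyl group is compound 1 at 34% and no measured compound carries 4-carbamoylphenyl, so a large fall is expected, though its size remains uncertain. The estimated change is a number 60 percentage points lower from compound 2 to compound 3 (beyond the scatter) and lies beyond the scatter. In this assay compound 3 is expected at 40% with an estimated range from 12% to 80% for the coming measurement.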

Compound 3, percent growth inhibition at one concentration: 100%
For compound 3 the middle estimate is 60 percentage points below the measured one, and the stated range ends below it.
By their numbers in this assay, from the lowest: compound 1; then compounds 2 and 3 (each within the scatter of the next).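

Replacing 2-(hydroxymethyl)phenyl with 4-carbamoylphenyl on the aromatic nitrogen gives no change at the digits printed from compound 2 to compound 3 (within the scatter) in this assay, so the high read-out at this position does not depend on the 2-(hydroxymethyl)phenyl group. Measured against 3-(hydroxymethyl)phenyl, the same group gives a number 66 percentage points higher from compound 1 to compound 3 (beyond the scatter), which leaves compound 1 as the only one of the three standing apart from the others. Nothing available accounts for the difference between these groups or for the match between compound 2 and compound 3.

The compounds shown leave open whether the carbamoyl group needs its place in the 4-carbamoylphenyl group, as 3-carbamoylphenyl or 2-carbamoylphenyl would show. They also leave open how 4-(hydroxymethyl)phenyl, or a carboxylic acid or an aminomethyl group in place of the carbamoyl, would read in this assay.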